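The compounds below may be only part of what the source reports. "The series", "measured", "known", "first", "only" and "open" are said of these compounds alone.

Compounds measured so far:
compound 1, `CC(C)(C)NC(=O)/C=C/c1ccccc1`: 73%
compound 2, `CCCNC(=O)/C=C/c1ccccc1`: 63%

In a functional assay on the whole organism for inhibition, with Brassica rapa subsp. chinensis as the target, with a stated time of 3 days, tested at 100 ppm (on this read-out lower numbers stand for less inhibition of growth and higher numbers for more inhibition of growth at the one concentration tested), compound 2 gives the lower of the two numbers; its nearest neighbour is compound 1, and the change a number 10 percentage points lower from compound 1 to compound 2 (within the scatter) lies within the scatter. Compound 3, `CCCCOC(=O)/C=C/c1ccccc1`, differs from compound 2 by butoxy in place of propylamino on a carbonyl carbon. Within the data shown here, no measured step covers such a change at the carbonyl carbon; the only step available, a number 10 percentage points lower from compound 1 to compound 2 (within the scatter), altered the group on the nitrogen and stayed within the scatter, so nothing points to a shift beyond the scatter. The step from compound 2 to compound 3 is expected to be a number 3 percentage points lower from compound 2 to compound 3 (within the scatter). Compound 3 is therefore estimated at 60%, within a range of 35% to 85%.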

Compound 3, percent growth inhibition at one concentration: 0%
For compound 3 the middle estimate is 60 percentage points above the measured one, outside the stated range (below it).
By their numbers in this assay, from the lowest: compound 3; then compounds 2 and 1 (each within the scatter of the next).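

In this assay, the group on the carbonyl carbon decides the outcome: butoxy in place of propylamino gives a number 63 percentage points lower from compound 2 to compound 3 (beyond the scatter), and butoxy in place of (tert-butyl)amino gives a number 73 percentage points lower from compound 1 to compound 3 (beyond the scatter). Changing only the group on the nitrogen, by contrast, gave a number 10 percentage points lower from compound 1 to compound 2 (within the scatter). Nothing available explains this loss of growth inhibition. The compounds shown leave open whether the loss goes with the oxygen replacing the nitrogen or with the longer chain. Butylamino or propoxy on the same carbonyl carbon would separate these two changes.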